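Hydroxamate Inhibitors of HDAC6: From Compound 2 to Compound 4

A few compounds are considered here, and "the series" means these few. Any claim that something is new, unique, unknown or untested is made for them only; others in the source may bear on it.

Three hydroxamic acids have been measured in an assay on Sf9 cells for inhibition of protein deacetylase HDAC6 (Homo sapiens), read by fluorescence; a lower number here means a stronger inhibitor, a higher number a weaker inhibitor. Compound 1 `O=C(NO)c1ccc(Cc2noc(-c3ccccc3)n2)cc1` gives 6 nM, compound 3 `Cn1c(Sc2c(F)cc(C(=O)NO)cc2F)nnc1-c1cccnn1` gives 13 nM, and compound 2 `O=C(NO)c1ccc(Cn2nnc(Cc3ccccn3)n2)cc1` gives 25 nM. Compound 2 thus has the highest number of the three: its gap to compound 3 lies within the scatter of repeated measurements, whereas its gap to compound 1 lies beyond it, so only compound 1 is clearly the stronger inhibitor of the pair.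

Compound 4 `NCc1ccc(-c2nnn(Cc3ccc(C(=O)NO)cc3)n2)cc1` has not yet been measured. It differs from compound 2 in one place: 4-(aminomethyl)phenyl in place of (pyridin-2-yl)methyl on an aromatic carbon. The hydroxamic acid and the benzylic link to the five-membered aromatic ring with 4 nitrogen are kept, and only the group on that ring changes. For the measured compounds named here, no measured pair shows this change, so there is no direct precedent for its size. The closest guidance is the narrow spread among compounds 1, 2 and 3, whose numbers all fall in the same region despite different groups in this position.

For that reason compound 4 is expected to show no step beyond the scatter, a 1.4-fold lower number from compound 2 to compound 4 (0.14 log units; within the scatter), with an estimated value in this assay of 18 nM and a range from 6 nM to 55 nM.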

Compound 4, half-maximal inhibitory concentration: 2 nM
The estimate for compound 4 lay 9.0-fold (0.95 log units) above the measured number; the whole stated range lies above it.
By their numbers in this assay, from the lowest: compound 4; then compound 1; then compounds 3 and 2 (each within the scatter of the next).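

In this assay, the group on the aromatic carbon of the five-membered aromatic ring with 4 nitrogen can shift the number well beyond the scatter: 4-(aminomethyl)phenyl in place of (pyridin-2-yl)methyl gives a 13-fold lower number from compound 2 to compound 4 (1.10 log units; beyond the scatter). The earlier compounds shown here could not show this, as no two of them differed in only one place. The change replaces a six-membered aromatic ring with 1 hetero atom by one of carbon only and adds a hydrogen-bond donor, but nothing available here shows what lies behind the step.

The compounds shown do not separate the contribution of the amine from that of the ring. Plain phenyl, 4-(hydroxymethyl)phenyl or 4-carboxyphenyl at this position would be needed to tell them apart, and a longer chain carrying the amine remains untested here.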